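This account rests on a few compounds, and the source may have more. Where it says the series, first, only, none or still open, it means among the compounds named here.

Compound 3 `CC1=C(C(=O)SC(C)C)C(c2ccco2)NC(=O)N1` stands second highest of the three numbers in an assay on membranes from CHO cells for displacement of a labelled ligand from adenosine receptor A1 (Homo sapiens), read by scintillation counting, with a stated time of 60 min, tested at 1 uM (on this read-out lower numbers stand for less inhibition and higher numbers for more inhibition at the one concentration tested (going by the name of the read-out)), where compound 3 gives 5%. Its nearest neighbour is compound 2 `CCSC(=O)C1=C(C)NC(=O)NC1c1ccco1`, which in this assay gives 6%; furthest is compound 1 `CCNC(=O)C1=C(C)NC(=O)NC1c1ccco1`, which in this assay gives 2%. The unmeasured compound 4 `CCC(C)OC(=O)C1=C(C)NC(=O)NC1c1ccco1` differs from compound 3 by sec-butoxy in place of isopropylsulfanyl on a carbonyl carbon. For the measured compounds named here, the steps that bear on this change are those that swap the group on the same carbonyl carbon: a number 4 percentage points higher from compound 1 to compound 2 (within the scatter) and a number 3 percentage points higher from compound 1 to compound 3 (within the scatter), together with a number 1 percentage points lower from compound 2 to compound 3 (within the scatter). All of these lie within the scatter, so for compound 4 he expects no step beyond the scatter, namely no change at the digits printed from compound 3 to compound 4 (within the scatter). His estimate for compound 4 in this assay is therefore 5%, with a range from 0% to 14%.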

Compound 4, a percentage reported as inhibition, at one concentration (the size of the read-out at that concentration, not a potency): 6%
Compound 4: middle estimate off by 1 percentage points, on the low side; the measured number falls inside the stated range.
By their numbers in this assay, from the lowest: compounds 1, 3, 2 and 4 (each within the scatter of the next).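

In this assay, sec-butoxy on the carbonyl carbon gives a number 1 percentage points higher from compound 3 to compound 4 (within the scatter) and no change at the digits printed from compound 2 to compound 4 (within the scatter) and a number 4 percentage points higher from compound 1 to compound 4 (within the scatter). For the compounds shown here, an oxygen-linked group thus joins the nitrogen-linked and sulfur-linked groups at this position, and no step among the four compounds leaves the scatter. No evidence is at hand to account for these numbers.

As far as these compounds go, whether a carboxylic acid, a benzyloxy group or a longer chain on this carbonyl carbon would move the number beyond the scatter stays open.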